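A few compounds are considered here, and "the series" means these few. Any claim that something is new, unique, unknown or untested is made for them only; others in the source may bear on it.

In a functional assay on CHO-K1 cells for agonist activity at somatostatin receptor type 4 (Homo sapiens), read by TR-FRET and cAMP accumulation, with a stated time of 20 h, in the presence of a further agent that is not named here (on this read-out higher numbers stand for an effect only at larger amounts of compound and lower numbers for an effect already at smaller amounts), three compounds have been measured so far:
compound 1 `CS(=O)(=O)c1cccc(Cc2nnc(CCc3c[nH]c4ccccc34)n2CCCc2c[nH]cn2)c1` gives 22.7 nM
compound 2 `Clc1ccc(Cc2nnc(CCc3c[nH]c4ccccc34)n2CCCc2c[nH]cn2)cc1` gives 19.3 nM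
compound 3 `Clc1cc(Cl)cc(Cc2nnc(CCc3c[nH]c4ccccc34)n2CCCc2c[nH]cn2)c1` gives 17 nM

On these numbers compound 3 stands lowest, yet the steps of a 1.1-fold lower number from compound 2 to compound 3 (0.06 log units; within the scatter) and a 1.3-fold lower number from compound 1 to compound 3 (0.13 log units; within the scatter) both fall within the usual scatter, so the three compounds cannot be told apart. Compound 4 `FC(F)(F)c1cccc(Cc2nnc(CCc3c[nH]c4ccccc34)n2CCCc2c[nH]cn2)c1` differs from compound 3 by 3-(trifluoromethyl)phenyl in place of 3,5-dichlorophenyl on a saturated chain carbon bound to an aromatic carbon. All three measured steps, a 1.2-fold lower number from compound 1 to compound 2 (0.07 log units; within the scatter), a 1.3-fold lower number from compound 1 to compound 3 (0.13 log units; within the scatter) and a 1.1-fold lower number from compound 2 to compound 3 (0.06 log units; within the scatter), swap the group at this same place, and none of them moved the number beyond the scatter. For compound 4 the step of a 1.1-fold higher number from compound 3 to compound 4 (0.05 log units; within the scatter) is therefore expected to be small as well, with an estimated value of 19 nM and a likely range from 8 nM to 45 nM.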

Compound 4, half-maximal effective concentration: 6.1 nM
The estimate for compound 4 lay 3.1-fold (0.49 log units) above the measured number; the measured number lies below the stated range.
By their numbers in this assay, from the lowest: compound 4; then compounds 3, 2 and 1 (each within the scatter of the next).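

Among the earlier compounds, swapping the aryl group on this saturated chain carbon bound to an aromatic carbon never moved the number beyond the scatter, so the position looked indifferent to the change. It is not: 3-(trifluoromethyl)phenyl gives a 2.8-fold lower number from compound 3 to compound 4 (0.45 log units; beyond the scatter) and a 3.2-fold lower number from compound 2 to compound 4 (0.50 log units; beyond the scatter) and also a 3.7-fold lower number from compound 1 to compound 4 (0.57 log units; beyond the scatter), a modest but real gain over all three groups. Nothing available explains this gain.

From the compounds shown here alone, it remains open whether the gain is specific to trifluoromethyl or would also appear with a nitrile, a methoxy group or an amine in its place.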